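Amine substituent exchange and tolerated concentration in the series

This account rests on a few compounds, and the source may have more. Where it says the series, first, only, none or still open, it means among the compounds named here.

Compound 1 `Cc1ccc2[nH]c(=O)c(CN(Cc3ccc(O)cc3)Cc3ccc(C(C)(C)C)cc3)cc2c1` gives 4900 nM in a toxicity assay on MDCK cells (Canis lupus familiaris) for cytotoxicity, read by crystal violet staining, with a stated time of 48 h; a higher number here means that more compound is tolerated, a lower number that less compound is tolerated. Compound 2 `CCOc1ccc(CN(Cc2ccc(C(C)(C)C)cc2)Cc2cc3cc(C)ccc3[nH]c2=O)cc1` reaches only the limit of > 10000 nM in this assay. Compound 3 `Cc1ccc2[nH]c(=O)c(CN(Cc3ccc(C(N)=O)cc3)Cc3ccc(C(C)(C)C)cc3)cc2c1` likewise reaches only the limit of > 5000 nM in this assay; with one further value also a limit, its place among the three cannot be ranked. Compound 4 `Cc1ccc2[nH]c(=O)c(CN(Cc3ccc(C(C)(C)C)cc3)[C@H](CO)c3ccccc3)cc2c1` differs from compound 3 by 2-hydroxy-1-phenylethyl in place of 4-carbamoylbenzyl on an amine nitrogen. Of the measured steps, an at least 2.0-fold higher number from compound 1 to compound 2 (0.30 log units; that floor lies within the scatter) and an at least 1.0-fold higher number from compound 1 to compound 3 (0.00 log units; that floor lies within the scatter) bear on the same part of the structure and both are floors within the scatter, while a step that the two limits leave unreadable from compound 2 to compound 3 cannot be read. Going by the values given here, no step therefore points to a movement beyond the scatter, and compound 4 is expected at 5000 nM, between 2000 nM and 12000 nM, a step of a number no higher from compound 3 to compound 4 (the limit leaves the size open) expected to stay within the scatter.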

Compound 4, half-maximal cytotoxic concentration: > 10000 nM
Compound 4: no number, only a limit; the forecaster's own chance of this, stated with the estimate: 50%; at least 2.0-fold (0.30 log units) between middle value and limit.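

On the amine nitrogen, 2-hydroxy-1-phenylethyl, with its defined stereocentre, takes the place of the substituted benzyl groups, and in this assay compound 4 gives only a limit, > 10000 nM. This exchange gives an at least 2.0-fold higher number from compound 1 to compound 4 (0.30 log units; that floor lies within the scatter). The steps to compound 2 and compound 3 cannot be read, and the upper end of the series stays unresolved: the limit of > 10000 nM in this assay, at which 2 of the 4 values shown sit.

Open, going by these compounds, is whether the mirror-image form of 2-hydroxy-1-phenylethyl behaves alike. Also open, on these data alone, is whether an amine or a carboxylic acid in place of its hydroxy gives a number rather than a limit.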